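Swapping bromo for methoxy on the shared core

The source may report more compounds than this note shows. Statements on the series, on what has been measured and on what is new or still open speak of the compounds shown alone.

In an ADME assay on Vero cells (Chlorocebus sabaeus) for cytotoxicity, read by sulforhodamine B assay, with a stated time of 48 h (a lower number here means a stronger inhibitor of growth, a higher number a weaker inhibitor of growth), compound 1 `COc1ccc(/C(Cl)=C/C=C(\C#N)C(=O)c2c[nH]c3ccc(Br)cc23)cc1OC` gives 38400 nM, and compound 2 `COc1cc(/C(Cl)=C/C=C(\C#N)C(=O)c2c[nH]c3ccc(Br)cc23)cc(OC)c1OC` gives 22100 nM. Within the data shown here, the only measured step, a 1.7-fold lower number from compound 1 to compound 2 (0.24 log units; within the scatter), is a methoxy addition, so compound 2 stands alongside compound 1 within the scatter. Compound 3 `COc1ccc2[nH]cc(C(=O)/C(C#N)=C/C=C(\Cl)c3cc(OC)c(OC)c(OC)c3)c2c1` differs from compound 2 by methoxy in place of bromo on an aromatic carbon. Among the measured compounds shown here, no measured step replaces bromo with methoxy, so nothing here points to a change; the step of a 1.0-fold lower number from compound 2 to compound 3 (0.00 log units; within the scatter) is therefore expected to stay within the scatter. For compound 3 the expected value in this assay is 22000 nM, estimated to fall between 9000 nM and 55000 nM.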

Compound 3, concentration for total growth inhibition: 12100 nM
Compound 3: middle estimate off by 1.8-fold (0.26 log units), on the high side; measured number inside the range.
By their numbers in this assay, from the lowest: compounds 3, 2 and 1 (each within the scatter of the next, the first and the last beyond it).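

In this assay, putting methoxy in place of bromo on this aromatic carbon of the six-membered ring gives a 1.8-fold lower number from compound 2 to compound 3 (0.26 log units; within the scatter) and so stays within the scatter. At this position, then, the two groups leave compound 2 and compound 3 reading alike, which the earlier methoxy addition elsewhere on the molecule could not show. Nothing measured here explains this result. From the compounds shown here alone, whether an amine, a carboxylic acid or a longer chain on this same carbon would also stay within the scatter remains open.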